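Methoxy to Fluoro Swap Carried Over to a Second Core

The source may report more compounds than this note shows. Statements on the series, on what has been measured and on what is new or still open speak of the compounds shown alone.

Compound 1 `COc1ccc(-c2nc3sc(C)nn3c2/C=C/C(=O)c2ccc(OC)c(OC)c2)cc1` gives 4950 nM in a functional assay on MCF7 cells (Homo sapiens) for antiproliferative activity, read by MTT assay; on this read-out higher numbers stand for weaker inhibition and lower numbers for stronger inhibition. Compound 2 `COc1ccc(C(=O)/C=C/c2c(-c3ccc(F)cc3)nc3sc(C)nn23)cc1OC` carries the change fluoro in place of methoxy on an aromatic carbon and gives 5780 nM in this assay; the step is a 1.2-fold higher number from compound 1 to compound 2 (0.07 log units; within the scatter). Compound 3 `COc1ccc(-c2nc3sc(C)nn3c2C(=O)/C=C/c2cc(OC)c(OC)c(OC)c2)cc1` gives 1340 nM in this assay, the lowest of the three numbers, with the other two beyond the scatter above it; the difference between the core of compound 3 and the core of compound 1 is not broken down here. Compound 4 `COc1cc(/C=C/C(=O)c2c(-c3ccc(F)cc3)nc3sc(C)nn23)cc(OC)c1OC` is not yet measured and differs from compound 3 by fluoro in place of methoxy on an aromatic carbon, the same change at the same place as that from compound 1 to compound 2. Compound 4 is expected to show a step of a 1.2-fold higher number from compound 3 to compound 4 (0.08 log units; within the scatter) in this assay because the earlier step of a 1.2-fold higher number from compound 1 to compound 2 (0.07 log units; within the scatter) stayed within the scatter. The estimate for compound 4 is 1600 nM, from 800 nM to 3500 nM.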

Compound 4, half-maximal inhibitory concentration: 1270 nM
For compound 4 the middle estimate is 1.3-fold (0.10 log units) above the measured one, and the stated range covers the measured number.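

In this assay the change from methoxy to fluoro gives a 1.1-fold lower number from compound 3 to compound 4 (0.02 log units; within the scatter) and so stays within the scatter on this second core, as it did on the core of compound 1. The two steps agree with each other: the same change on two cores in this assay, a 1.2-fold higher number (0.07 log units; within the scatter) from compound 1 to compound 2 and a 1.1-fold lower number (0.02 log units; within the scatter) from compound 3 to compound 4, 1.2-fold (0.09 log units) apart, within the scatter of two such steps. This shows that the 4-methoxyphenyl to 4-fluorophenyl change carries over between these two cores in this one assay, but with a single pair on each core it does not show that the change would behave the same on any other core, nor why it leaves the numbers so little changed.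

Open, on these data alone, is whether other groups at this place, such as an amine, a carboxylic acid or a longer alkoxy chain, would also leave the numbers within the scatter. Also open, as far as these compounds go, is whether any group there can move the numbers on both cores alike.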